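Cytotoxicity of a thiazolyl pyrrolidinone analog

A few compounds are considered here, and "the series" means these few. Any claim that something is new, unique, unknown or untested is made for them only; others in the source may bear on it.

Compound 1: `O=C1CC(c2cnco2)CN1c1cnn2c1CN(C(=O)Nc1cc(F)c(F)c(F)c1)C(C1CC1)C2` gives 139000 nM
Compound 2: `O=C(Nc1cc(F)c(F)c(F)c1)N1Cc2c(-c3ccc(F)cc3F)cnn2CC1C1CC1` gives 32100 nM
Compound 3: `O=C1c2ccccc2CN1c1cnn2c1CN(C(=O)Nc1cc(F)c(F)c(F)c1)C(C1CC1)C2` gives 38500 nM

These three compounds were tested in a toxicity assay on HepG2 2.2.15 cells (Homo sapiens) for cytotoxicity, read by CellTiter-Glo; on this read-out lower numbers stand for higher toxicity in this test and higher numbers for lower toxicity in this test. Compound 3 stands second highest of the three numbers; its nearest neighbour is compound 2, whose number differs only within the scatter, while compound 1 is furthest, with a higher number.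

Compound 4, `O=C1CC(c2nccs2)CN1c1cnn2c1CN(C(=O)Nc1cc(F)c(F)c(F)c1)C(C1CC1)C2`, has not yet been measured. The change from compound 3 is a group of 11 heavy atoms (7 carbon, 2 nitrogen, 1 oxygen, 1 sulfur; one five-membered non-aromatic ring with 1 hetero atom, one five-membered aromatic ring with 2 hetero atoms) in place of a group of 10 heavy atoms (8 carbon, 1 nitrogen, 1 oxygen; one five-membered non-aromatic ring with 1 hetero atom, one six-membered aromatic ring of carbon only), on an aromatic carbon. The group that enters in compound 4 closely resembles the group carried by compound 1, which differs from it only in the five-membered aromatic ring. The step that bears on this change is a 3.6-fold lower number from compound 1 to compound 3 (0.56 log units; beyond the scatter), where the same group that leaves here replaced a very similar group and the number dropped. Running that step backwards, a modest rise in this assay is expected from compound 3 to compound 4, about a 2.9-fold higher number from compound 3 to compound 4 (0.46 log units; beyond the scatter). Compound 4 is therefore estimated at 110000 nM, with a range from 45000 nM to 250000 nM.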

Compound 4, half-maximal cytotoxic concentration: 115000 nM
For compound 4 the middle estimate is 1.0-fold (0.02 log units) below the measured one, within the range that was stated.
By their numbers in this assay, from the lowest: compounds 2 and 3 (each within the scatter of the next); then compounds 4 and 1 (each within the scatter of the next).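

On the aromatic carbon of the five-membered ring, the 2-oxo-4-(1,3-thiazol-2-yl)pyrrolidin-1-yl group gives a 3.0-fold higher number from compound 3 to compound 4 (0.48 log units; beyond the scatter) in this assay, and against 2,4-difluorophenyl it gives a 3.6-fold higher number from compound 2 to compound 4 (0.55 log units; beyond the scatter), so a second substituted pyrrolidinone now stands beyond the scatter from both groups without that ring. Exchanging 1,3-oxazol-5-yl for 1,3-thiazol-2-yl on the saturated ring carbon gives a 1.2-fold lower number from compound 1 to compound 4 (0.08 log units; within the scatter), so this pair shows no readable difference between the two aromatic rings. Nothing available here explains these numbers.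

Still open, as far as these compounds go, is how the number would respond if an amine or a carboxylic acid took the place of the aromatic ring on the pyrrolidinone. From the compounds shown here alone, all four compounds share one core, so whether these steps hold on another core also remains unknown.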